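The compounds below may be only part of what the source reports. "The series", "measured", "known", "first", "only" and "open" are said of these compounds alone.

Measured compounds:
- compound 1 `O=C1COc2ccc(-c3cnc(Cl)c(NS(=O)(=O)c4ccc(F)cc4)c3)cc2N1c1ccc(F)cc1`: in a functional assay on HCT-116 cells (Homo sapiens) for antiproliferative activity, read by MTT assay, with a stated time of 72 h (a lower number here means a stronger inhibitor, a higher number a weaker inhibitor), compound 1 gives 34200 nM
- compound 2 `COc1ncc(-c2ccc3c(c2)N(c2ccc(F)cc2)C(=O)CO3)cc1NS(=O)(=O)c1ccc(F)cc1`: compound 2 gives only a limit, > 40000 nM, which is the limit of > 40000 nM in this assay, at which 1 of the 3 values shown sits.
- compound 3 `COc1cccc(N2C(=O)COc3ccc(-c4cnc5ccccc5c4)cc32)c1`: compound 3 gives 8240 nM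

Compound 1 stands highest of the two numbers in this assay; compound 3 is the nearest, and its lower number lies beyond the scatter. Among the compounds with values here, the single measured step, an at least 1.1-fold higher number from compound 1 to compound 2 (0.06 log units; that floor lies within the scatter), is methoxy in place of chloro on an aromatic carbon and ends at a limit, so its floor lies within the scatter.

Compound 4 `Cc1ccc(N2C(=O)COc3ccc(-c4cnc(Cl)c(NS(=O)(=O)c5ccc(F)cc5)c4)cc32)cc1` is not yet measured. It differs from compound 1 by methyl in place of fluoro on an aromatic carbon, para to a large group. Within the data shown here, no measured step touches this position; the only step recorded, from compound 1 to compound 2, changes a different part of the core and therefore does not bear on it. With nothing in the series speaking for a shift in either direction, the expected step is none beyond the scatter: compound 4 is estimated at a 1.1-fold lower number from compound 1 to compound 4 (0.06 log units; within the scatter) against compound 1. Compound 4 is therefore expected to give about 30000 nM, in the range 12000 nM to 80000 nM, with a fair chance that only a limit is reported.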

Compound 4, half-maximal inhibitory concentration: 34300 nM
Estimate against measurement, compound 4: 1.1-fold (0.06 log units) below, within the range that was stated.
By their numbers in this assay, from the lowest: compound 3; then compounds 1 and 4 (each within the scatter of the next). At a limit, above all of these: compound 2.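

In this assay, the exchange of 4-fluorophenyl for 4-methylphenyl gives a 1.0-fold higher number from compound 1 to compound 4 (0.00 log units; within the scatter). Within the data shown here, this is the first reading at this position, on an aromatic carbon of a six-membered aromatic ring of carbon only, para to a large group; the earlier step, methoxy in place of chloro, lay in a different part of the core and ended at a limit. For this one pair, methyl in place of fluoro leaves the antiproliferative read-out without a change beyond the scatter, and nothing measured here bears on why that is so.

Only fluoro and methyl are shown at this position, so it remains open whether an amine, a carboxylic acid or a longer chain such as butyl would also leave the read-out flat, and the pair does not show how far this tolerance extends. Also open, as far as these compounds go, is whether methyl in place of fluoro stays flat with methoxy in place of chloro, as in compound 2, whose reading is only a limit.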